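Sugar hydroxyl and topoisomerase inhibition across two cores

A few compounds are considered here, and "the series" means these few. Any claim that something is new, unique, unknown or untested is made for them only; others in the source may bear on it.

Compound 1 `Cc1ccc(S(=O)(=O)n2c(-c3ccccc3)c(C#CCO[C@H]3CC[C@H](N)[C@H](C)O3)c3ccccc32)cc1` and compound 2 `Cc1ccc(S(=O)(=O)n2c(-c3ccccc3)c(C#CCO[C@H]3C[C@H](N)[C@H](O)[C@H](C)O3)c3ccccc32)cc1` share one core and differ only in the sugar-like ring attached through an ether oxygen. In an assay on isolated protein for inhibition of DNA topoisomerase 1 (Homo sapiens), with a stated time of 30 min, tested at 100 uM (a higher number here means more inhibition at the concentration tested (going by the name of the read-out), a lower number less inhibition), compound 1 gives 43.2% and compound 2 gives 80.1%. The change between them is a group of 9 heavy atoms (6 carbon, 1 nitrogen, 2 oxygen; one six-membered non-aromatic ring with 1 hetero atom) in place of a group of 8 heavy atoms (6 carbon, 1 nitrogen, 1 oxygen; one six-membered non-aromatic ring with 1 hetero atom), on an oxygen on a saturated carbon, and the step it made was a number 36.9 percentage points higher from compound 1 to compound 2 (beyond the scatter).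

Compound 3 `C[C@@H]1O[C@@H](OCC#Cc2c(-c3ccccc3)sc3ccccc23)CC[C@@H]1N` carries a different core, and the difference between the two cores is not broken down here. In this assay compound 3 gives 7.9%, the lowest number among the three measured compounds, sitting beyond the scatter below both compound 1 and compound 2.

Compound 4 `C[C@@H]1O[C@@H](OCC#Cc2c(-c3ccccc3)sc3ccccc23)C[C@H](N)[C@@H]1O` is compound 3 with the same change that turned compound 1 into compound 2: a group of 9 heavy atoms (6 carbon, 1 nitrogen, 2 oxygen; one six-membered non-aromatic ring with 1 hetero atom) in place of a group of 8 heavy atoms (6 carbon, 1 nitrogen, 1 oxygen; one six-membered non-aromatic ring with 1 hetero atom), on an oxygen on a saturated carbon. The change sits at the same place in both pairs, on an oxygen on a saturated carbon, so it is the same change, seen twice among these compounds.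

Among the compounds with values here, for compound 4 the step from compound 3 is expected to be upward, a number 27.1 percentage points higher from compound 3 to compound 4 (beyond the scatter), resting on the single earlier step of a number 36.9 percentage points higher from compound 1 to compound 2 (beyond the scatter) on a core that is not the core of compound 3, so less is taken for granted. The estimate for compound 4 in this assay is therefore 35%, with a plausible range from 10% to 62%.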

Compound 4, a percentage reported as inhibition, at one concentration (the size of the read-out at that concentration, not a potency): 36.9%
The estimate for compound 4 lay 1.9 percentage points below the measured number; low and high end bracket the measured number.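

In this assay, exchanging the 5-amino-6-methyloxan-2-yl group for the ring carried by compound 4, on an oxygen on a saturated carbon, gave a number 29 percentage points higher from compound 3 to compound 4 (beyond the scatter), so the upward step seen on the core of compound 1 appeared again on the core of compound 3. Set beside the earlier step, the new one runs in the same direction and the two cannot be told apart in size: the same change on two cores in this assay, a number 36.9 percentage points higher (beyond the scatter) from compound 1 to compound 2 and a number 29 percentage points higher (beyond the scatter) from compound 3 to compound 4, 7.9 percentage points apart, within the scatter of two such steps. Within the data shown here, this shows that the change carried over between these two cores in this assay, but it rests on only one pair per core, each read at a single concentration, so it shows neither that the step would hold on any further core nor why the change raises the inhibition.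

The compounds shown leave open which part of the entering group accounts for the step, since no compound here separates the added ring hydroxyl from the other differences between the two rings. They also leave open whether the step would survive with a methoxy group in place of that hydroxyl, a dimethylamino group in place of the amine, or a longer chain between the ring and the core.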